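A few compounds are considered here, and "the series" means these few. Any claim that something is new, unique, unknown or untested is made for them only; others in the source may bear on it.

The measured compounds in a functional assay on the whole organism (strain NMRI BR) with Mus musculus as the target (a lower number here means that less compound is needed, a higher number that more compound is needed for the effect), are these:
Compound 1, `O=C1C=C(N2CCCC2)CN1c1ccc(Cl)cc1`, gives only a limit of the assay, > 300 mg/kg.
Compound 2, `O=C1C=C(N2CCNCC2)CN1c1ccc(Cl)cc1`, gives 58.2 mg/kg.
Compound 3, `O=C1C=C(N2CCNCC2)C(=O)N1c1ccc(Cl)cc1`, gives 360 mg/kg.

Compound 2 and compound 1 share one core and differ in a single place: pyrrolidin-1-yl in place of piperazin-1-yl on a double-bonded ring carbon. That change produced an at least 5.1-fold higher number from compound 2 to compound 1 (0.71 log units; beyond the scatter), a step whose size cannot be fixed more closely, since compound 1 sits at the limit of > 300 mg/kg in this assay, at which 1 of the 3 values shown sits.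

Compound 3 has a different core from compound 2; the difference between the two cores is not broken down here. Among the numbers measured, compound 3 gives the highest, and compound 2 gives a lower number by a margin beyond the scatter.

Compound 4, `O=C1C=C(N2CCCC2)C(=O)N1c1ccc(Cl)cc1`, has not yet been measured in this assay. It differs from compound 3 in the same place and by the same change as compound 1 differs from compound 2: pyrrolidin-1-yl in place of piperazin-1-yl on a double-bonded ring carbon. Because the earlier step was an at least 5.1-fold higher number from compound 2 to compound 1 (0.71 log units; beyond the scatter), the same change on the core of compound 3 is expected to weaken the effect again, from a starting point that is already the weakest measured. The estimated step from compound 3 to compound 4 in this assay is a 4.2-fold higher number from compound 3 to compound 4 (0.62 log units; beyond the scatter). Compound 4 is therefore expected to give about 1500 mg/kg, most likely between 500 mg/kg and 5000 mg/kg, and it may well be reported only as a limit of the assay.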

Compound 4, dose for half-maximal effect in the Mus musculus assay: > 300 mg/kg
Compound 4: only a limit was reported; the forecaster's own chance of this, stated with the estimate: 60%; the middle value is on the limit's open side.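

In the Mus musculus assay compound 4 gives > 300 mg/kg, which is a limit of the assay and not a number. For the compounds shown here, the step from compound 3 to compound 4 cannot be read, so this pair adds no new step. The compounds shown leave open how large the effect of pyrrolidin-1-yl in place of piperazin-1-yl is on the core of compound 3, and whether it matches the step seen on the core of compound 2. In a physicochemical assay for lipophilicity (on this read-out higher numbers stand for higher lipophilicity and lower numbers for lower lipophilicity), compound 3 gives 3.4 and compound 4 gives 3.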